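The source may report more compounds than this note shows. Statements on the series, on what has been measured and on what is new or still open speak of the compounds shown alone.

Working notes on the series. In an ADME assay on MRC5 cells (Homo sapiens) for cytotoxicity, read by fluorescence, with a stated time of 72 h (on this read-out higher numbers stand for weaker inhibition and lower numbers for stronger inhibition), compound 1 `CC1(COc2ccc(-c3ccc(F)nc3)nc2)Cn2cc([N+](=O)[O-])nc2O1` gives > 64000 nM, which is a limit of the assay and not a number. Compound 2 `CC1(COc2ccc(OC(F)(F)F)cc2)Cn2nc([N+](=O)[O-])nc2O1` gives > 64000 nM, also a limit and not a number. The measured data therefore amount to the limit of > 64000 nM in this assay, at which 2 of the 2 values shown sit, and compound 2 has no exact position in the series.

Compound 3 `CC1(COc2ccc(OC(F)(F)F)cc2)Cn2nc(Br)nc2O1` has bromo in place of nitro on an aromatic carbon. Going by the values given here, no measured pair shows the effect of this change. The expectation rests only on compound 2, whose reading of > 64000 nM is a limit. No change beyond the scatter is expected in this assay, and any real shift would most likely be toward stronger inhibition. The estimated size of the step is an at least 1.0-fold lower number from compound 2 to compound 3 (0.02 log units; that floor lies within the scatter). For compound 3 the estimated value is 60000 nM, with an expected range of 25000 nM to 64000 nM.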

Compound 3, half-maximal inhibitory concentration: 43000 nM
The estimate for compound 3 lay 1.4-fold (0.14 log units) above the measured number; low and high end bracket the measured number.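

In this assay compound 3 gives 43000 nM, the only exact number among the compounds shown, so with bromo on this aromatic carbon, between two ring nitrogen atoms, the read-out falls inside the range of the assay. Bromo in place of nitro at this place gives an at least 1.4-fold lower number from compound 2 to compound 3 (0.17 log units; that floor lies within the scatter), so the change does not establish a real shift toward stronger inhibition. Compound 1 and compound 2 stay at a limit, which is not a number: the limit of > 64000 nM in this assay, at which 2 of the 3 values shown sit.

From the compounds shown here alone, the true distance between compound 2 and compound 3 remains open, as the nitro side of the pair has only a limit. Also open, going by these compounds, is whether an amine or a chloro group at this place would give an exact number or return to the limit.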